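Aromatic ring in place of branched alkyl on the chain carbon

This account rests on a few compounds, and the source may have more. Where it says the series, first, only, none or still open, it means among the compounds named here.

In an in vitro functional assay on cells for agonist activity at Bombesin receptor subtype-3 (Homo sapiens), read by luminescence and calcium flux (a higher number here means that more compound is needed for the effect, a lower number that less compound is needed), compound 3 `CCC(C)(CC)Cc1cnc(CCc2ccc(-c3ccccc3C(=O)O)cc2)[nH]1` gives 76 nM. Compound 1 `Cc1ccccc1Cc1cnc(CCc2ccc(-c3ccccc3C(=O)O)cc2)[nH]1` gives 127 nM in this assay and stands nearest: a 1.7-fold lower number from compound 1 to compound 3 (0.22 log units; within the scatter). Compound 2 `O=C(O)c1ccccc1-c1ccc(CCc2ncc(CCc3ccccc3)[nH]2)cc1` gives 1320 nM and stands furthest: a 17-fold lower number from compound 2 to compound 3 (1.24 log units; beyond the scatter). Between the other two, a 10-fold higher number from compound 1 to compound 2 (1.02 log units; beyond the scatter).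

Compound 4 `O=C(O)c1ccccc1-c1ccc(CCc2ncc(Cc3cccc(Cl)c3)[nH]2)cc1` is not yet measured. Its change from compound 3 is 3-chlorophenyl in place of 1-ethyl-1-methylpropyl on a saturated chain carbon bound to an aromatic carbon. Going by the values given here, two measured steps bear on this. Compound 1 carries 2-methylphenyl on the same saturated chain carbon, an aromatic ring bound directly as in compound 4, and in this assay a 1.7-fold lower number from compound 1 to compound 3 (0.22 log units; within the scatter). Compound 2 carries benzyl there, the ring set one bond further out, and a 17-fold lower number from compound 2 to compound 3 (1.24 log units; beyond the scatter). Compound 4 matches the arrangement of compound 1 rather than compound 2, so the step that stayed within the scatter is the closer guide, while the compound 2 result warns that an aromatic group at this position can cost much more. The step in this assay is therefore expected to be small and towards a higher number, a 2.0-fold higher number from compound 3 to compound 4 (0.30 log units; within the scatter). Compound 4 is estimated at 150 nM, with a range from 50 nM to 500 nM.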

Compound 4, half-maximal effective concentration: 825 nM
Beside the measured number, compound 4's estimate is 5.5-fold (0.74 log units) below it; measured number above the stated range.
By their numbers in this assay, from the lowest: compounds 3 and 1 (each within the scatter of the next); then compounds 4 and 2 (each within the scatter of the next).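

In this assay, an aromatic ring bound directly to the saturated chain carbon does not by itself keep a compound in the range of the branched alkyl group, as an 11-fold higher number from compound 3 to compound 4 (1.04 log units; beyond the scatter) shows. Against this stands a 1.7-fold lower number from compound 1 to compound 3 (0.22 log units; within the scatter). With the ring bound in the same way in both compounds, the exchange of 2-methylphenyl for 3-chlorophenyl alone gives a 6.5-fold higher number from compound 1 to compound 4 (0.81 log units; beyond the scatter) and so shows that the ring's substitution matters at this position, which compounds 1 to 3 could not show. Moving the ring one bond further out no longer stands as the only aromatic change with a large cost, since a 1.6-fold lower number from compound 2 to compound 4 (0.20 log units; within the scatter) places compound 4 with compound 2 and leaves compound 1 as the one aromatic example close to compound 3.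

The compounds shown do not separate the effect of the methyl group from that of the chlorine, and unsubstituted phenyl or a cyclohexyl ring on the same saturated chain carbon would bear on that question. Nothing in the available data gives a reason for these steps.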